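Chloro for fluoro in the cytotoxicity series

The source may report more compounds than this note shows. Statements on the series, on what has been measured and on what is new or still open speak of the compounds shown alone.

In a functional assay on MT4 cells (Homo sapiens) for cytotoxicity, read by MTT assay (on this read-out higher numbers stand for lower toxicity in this test and lower numbers for higher toxicity in this test), compound 1 (`Cc1c(O)nc(SCc2ccc([N+](=O)[O-])cc2)nc1Cc1c(Cl)cccc1Cl`) gives > 58000 nM as a limit of the assay. Compound 2 (`CCOc1ccc(CSc2nc(O)c(C)c(Cc3c(Cl)cccc3Cl)n2)cc1`) gives > 58000 nM as a limit as well. Compound 3 (`Cc1c(O)nc(SCc2cccc(F)c2)nc1Cc1c(Cl)cccc1Cl`) gives > 61000 nM as a limit too, so no number is known for it, as for the other two.

Compound 4 (`Cc1c(O)nc(SCc2cccc(Cl)c2)nc1Cc1c(Cl)cccc1Cl`) differs from compound 3 by chloro in place of fluoro on an aromatic carbon and is otherwise identical. Going by the values given here, three measured steps bear on this change (a step that the two limits leave unreadable from compound 1 to compound 2 and a step that the two limits leave unreadable from compound 1 to compound 3 and a step that the two limits leave unreadable from compound 2 to compound 3) and none of them has a readable size. Among the compounds with values here, none of these exchanges on the aromatic ring has yielded a number so far. No step beyond the scatter is therefore expected in this assay in either direction. The estimated step is an at least 1.0-fold lower number from compound 3 to compound 4 (0.00 log units; that floor lies within the scatter) on this reasoning. Compound 4 is estimated at 60000 nM with an expected range from 25000 nM to 100000 nM and may again return only a limit.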

Compound 4, half-maximal cytotoxic concentration: > 59000 nM
Compound 4: a limit, no number (the forecaster's own chance of this, stated with the estimate: 70%); the middle value does not contradict the limit.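

Compound 4 gives > 59000 nM, a limit and not a number. Its steps from compound 1, compound 2 and compound 3 cannot be read. The compounds shown leave open how far any of these four differ in this assay, including chloro against fluoro.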